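Cyano for phenyl, with only limits around it

This account rests on a few compounds, and the source may have more. Where it says the series, first, only, none or still open, it means among the compounds named here.

Compound 1, `COC(=O)c1ccc(NCc2cncn2Cc2ccccc2-c2ccccc2)cc1-c1ccccc1`, has no result in a toxicity assay on NIH3T3 cells (Mus musculus) for cytotoxicity, read by resazurin assay; a lower number here means that less compound is needed, a higher number that more compound is needed for the effect; its entry there reads "not determined" (no result reported). Two related compounds have been measured. Compound 2, `c1ccc(-c2ccc(Cn3cncc3CNc3ccccc3-c3ccccc3)cc2)cc1`, reaches only a limit of the assay in this assay, at > 10000 nM. Compound 3, `c1ccc(-c2ccc(Cn3cncc3CNc3ccc(-c4noc5ccccc45)c(-c4ccccc4)c3)cc2)cc1`, likewise stops at a limit in this assay, with > 10000 nM. Compound 1 thus stands without a number of its own, and the two values beside it are both the same thing: the limit of > 10000 nM in this assay, at which 2 of the 3 values shown sit.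

Compound 4, `COC(=O)c1ccc(NCc2cncn2Cc2ccccc2C#N)cc1-c1ccccc1`, is the next compound to be measured. It differs from compound 1 in one place: cyano in place of phenyl on an aromatic carbon. Going by the values given here, no step between measured compounds carries this change, so nothing in the data fixes the size or the direction of the step from compound 1 to compound 4 in this assay; the working assumption is no movement beyond the scatter. With both measured compounds resting at the limit of > 10000 nM in this assay, at which 2 of the 3 values shown sit, compound 4 is expected to return a limit rather than a number. For compound 4 the estimated value in this assay is 15000 nM, expected to fall between 4000 nM and 60000 nM.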

Compound 4, half-maximal effective concentration: 25000 nM
Estimate against measurement, compound 4: 1.7-fold (0.22 log units) below; the measured number falls inside the stated range.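

Compound 1 has no number in this assay and compound 4 gives 25000 nM, so no step can be read between the two compounds. Still open, from the compounds shown here alone, is whether 2-phenylphenyl to 2-cyanophenyl moves the value in this assay at all, and in which direction.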